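Tetrabromobenzotriazoles with a hydroxyalkyl chain: from compound 2 to compound 3

The compounds below may be only part of what the source reports. "The series", "measured", "known", "first", "only" and "open" are said of these compounds alone.

Compound 1 `C[C@H](O)CCn1nc2c(Br)c(Br)c(Br)c(Br)c2n1` and compound 2 `CC(O)CCn1nc2c(Br)c(Br)c(Br)c(Br)c2n1` share a core and differ only in how a stereocentre is drawn. In a functional assay on CCRF-CEM cells (Homo sapiens) for antiproliferative activity, read by MTT assay, with a stated time of 48 h, tested at 25 uM (a higher number here means a weaker effect of the compound at the concentration tested, a lower number a stronger effect), compound 1 gives 89%, and compound 2 gives 86%; the step of a number 3 percentage points lower from compound 1 to compound 2 (within the scatter) is expected from the fact that one of compounds 1 and 2 is drawn with a defined configuration and the other without, at the place where they differ. Compound 2 thus holds the lowest of the two numbers, with compound 1 next to it within the scatter. Compound 3 `OCC(O)Cn1nc2c(Br)c(Br)c(Br)c(Br)c2n1` carries the change (1,2-dihydroxyethyl in place of 2-hydroxypropyl on a saturated chain carbon bound to an aromatic nitrogen). For the measured compounds named here, no measured step touches this change, so a step of a number 1 percentage points higher from compound 2 to compound 3 (within the scatter) is expected, no larger than the scatter. Compound 3 is estimated at 87%, between 70% and 100%.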

Compound 3, a percentage reported as activity, at one concentration (the size of the read-out at that concentration, not a potency): 56%
The estimate for compound 3 lay 31 percentage points above the measured number; measured number outside the range, below it.
By their numbers in this assay, from the lowest: compound 3; then compounds 2 and 1 (each within the scatter of the next).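

At this position, on a saturated chain carbon bound to an aromatic nitrogen, the identity of the chain changes the read-out in this assay, which the stereocentre drawing had not done. For the compounds shown here, putting 1,2-dihydroxyethyl in place of 2-hydroxypropyl gives the first step beyond the scatter (a number 30 percentage points lower from compound 2 to compound 3 (beyond the scatter); a number 33 percentage points lower from compound 1 to compound 3 (beyond the scatter)). Nothing available bears on what lies behind this step.

The compounds shown leave open whether an amine or a carboxylic acid in place of 1,2-dihydroxyethyl would give a similar step. They also leave open how a longer chain would read out.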